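Swapping the octyl chain for 2-chlorophenyl on the amine

This account rests on a few compounds, and the source may have more. Where it says the series, first, only, none or still open, it means among the compounds named here.

Compound 1 `CCCCCCCCNc1nc(SCc2ccc(C(F)(F)F)cc2)nc2ccccc12`: 12600 nM
Compound 2 `CCCCCCCCCCCCCCNc1nc(SCc2ccc(C(F)(F)F)cc2)nc2ccccc12`: > 50000 nM

Among the measured compounds shown here, in a functional assay on MGC-803 cells (Homo sapiens) for cytotoxicity, read by MTT assay, with a stated time of 72 h (a lower number here means a stronger inhibitor, a higher number a weaker inhibitor), compound 1 gives 12600 nM, the only number among the measured values. Compound 2 reaches only a limit in this assay, > 50000 nM, which is the limit of > 50000 nM in this assay, at which 1 of the 2 values shown sits. The step of an at least 3.9-fold higher number from compound 1 to compound 2 (0.59 log units; beyond the scatter) shows that lengthening the chain on the nitrogen weakens the compound. Compound 3 `FC(F)(F)c1ccc(CSc2nc(Nc3ccccc3Cl)c3ccccc3n2)cc1` differs from compound 1 by 2-chlorophenyl in place of octyl on a nitrogen on an aromatic ring. For the measured compounds named here, no measured step swaps the chain for an aromatic ring, so the single step on record, which concerns chain length only, bears on this change loosely: it shows that more chain on this nitrogen costs potency, not what a ring of similar size does. Compound 3 is therefore expected to stand near compound 1, with a step of a 1.4-fold lower number from compound 1 to compound 3 (0.15 log units; within the scatter) that is not expected to go beyond the scatter. The estimate for compound 3 is 9000 nM, ranging from 2500 nM to 35000 nM.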

Compound 3, half-maximal inhibitory concentration: > 50000 nM
Compound 3 gave a limit, no number; the forecaster's own chance of this, stated with the estimate: 15%; at least 5.5-fold (0.74 log units) between middle value and limit.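

In this assay, 2-chlorophenyl in place of octyl on this nitrogen gives an at least 3.9-fold higher number from compound 1 to compound 3 (0.59 log units; beyond the scatter), so the loss seen at this position is not confined to lengthening the chain, since an aromatic ring carrying chlorine also leaves the compound weaker than compound 1. Octyl is thus the only group shown here on this nitrogen that gives a number rather than a limit. The value for compound 3 is a limit, so the true size of the step stays unknown, and compound 3 stops at the same limit as compound 2: the limit of > 50000 nM in this assay, at which 2 of the 3 values shown sit.

Compound 2 and compound 3 therefore cannot be ranked against each other. Still open, going by these compounds, is whether a shorter chain such as butyl, an unsubstituted phenyl ring, or a chain ending in an amine on this nitrogen would match or exceed compound 1.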